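Sulfoxide for methoxy on a second core: expected dose

This account rests on a few compounds, and the source may have more. Where it says the series, first, only, none or still open, it means among the compounds named here.

Compound 1 `CCCOc1cc(OC)ccc1-c1nc2cc[nH]cc-2n1` gives 1.3 mg/kg in a functional assay on the whole organism with Canis familiaris (Canis lupus familiaris) as the target; a higher number here means that more compound is needed for the effect, a lower number that less compound is needed. Compound 2 `CCCOc1cc([S+](C)[O-])ccc1-c1nc2cc[nH]cc-2n1` carries the change a group of 3 heavy atoms (1 carbon, 1 oxygen, 1 sulfur; no ring) in place of a group of 2 heavy atoms (1 carbon, 1 oxygen; no ring), on an aromatic carbon and gives 1 mg/kg in this assay, a step of a 1.3-fold lower number from compound 1 to compound 2 (0.11 log units; within the scatter). Compound 3 `COc1ccc(-c2nc3c[nH]cnc-3n2)c(OC)c1` is built on a different core; the difference between the two cores is not broken down here. In this assay compound 3 gives 0.3 mg/kg, the lowest number of the three, with both other compounds beyond the scatter above it. Compound 4 `COc1cc([S+](C)[O-])ccc1-c1nc2c[nH]cnc-2n1` is not yet measured. It differs from compound 3 by a group of 3 heavy atoms (1 carbon, 1 oxygen, 1 sulfur; no ring) in place of a group of 2 heavy atoms (1 carbon, 1 oxygen; no ring), on an aromatic carbon, the same kind of change as from compound 1 to compound 2, though here the place is meta to a methoxy group rather than a propoxy group. Because the earlier step was a 1.3-fold lower number from compound 1 to compound 2 (0.11 log units; within the scatter), a step of about a 1.2-fold lower number from compound 3 to compound 4 (0.08 log units; within the scatter) is expected for compound 4. Compound 4 is therefore estimated at 0.25 mg/kg, between 0.12 mg/kg and 0.5 mg/kg.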

Compound 4, dose for half-maximal effect: 0.6 mg/kg
Beside the measured number, compound 4's estimate is 2.4-fold (0.38 log units) below it, outside the stated range (above it).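

On the core of compound 3, putting the sulfoxide group in place of the methoxy group gives a 2.0-fold higher number from compound 3 to compound 4 (0.30 log units; within the scatter) in this assay. Set beside the same change on the other core, the two steps do not differ by more than repeated measurements would be expected to: the same change on two cores in this assay, a 1.3-fold lower number (0.11 log units; within the scatter) from compound 1 to compound 2 and a 2.0-fold higher number (0.30 log units; within the scatter) from compound 3 to compound 4, 2.6-fold (0.41 log units) apart, within the scatter of two such steps. This fits a change that carries over between these two cores and moves the dose by no more than the scatter, but two small steps cannot prove that it does, and they say nothing about any further core.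

From the compounds shown here alone, it remains open how an amine or a carboxylic acid would behave at this place on either core. Also open, going by these compounds, is what a propoxy group would do in place of the remaining methoxy group of compound 4.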